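Exchanging the Sulfur Substituent of a Thioether Benzamide

The source may hold more compounds than are shown below. What is called first, only, known or untested is meant among the compounds shown, and "the series" means these compounds.

Measured compounds:
- compound 1, `COc1ccc(SCc2ccc(/C=C/C(=O)Nc3ccccc3N)cc2)cc1OC`: 65.5%
- compound 2, `Nc1ccccc1NC(=O)c1ccc(CSc2ccc(Br)cc2)cc1`: 33.2%
- compound 3, `COC(=O)c1ccccc1SCc1ccc(C(=O)Nc2ccccc2N)cc1`: 44.7%

Of the compounds shown here, three have been tested in a functional assay on A549 cells (Homo sapiens) for inhibition, read by CCK-8 assay, with a stated time of 72 h, tested at 2 uM; on this read-out lower numbers stand for less inhibition of growth and higher numbers for more inhibition of growth at the one concentration tested. Compound 1 gives 65.5%, compound 3 gives 44.7%, and compound 2 gives 33.2%. Compound 2 therefore stands lowest of the three; the nearest number is that of compound 3, which lies higher by a distance beyond the scatter, and the furthest is that of compound 1, higher still by a distance well beyond the scatter. Going by the values given here, none of the three pairs differs in only one place, so no single-change step between measured compounds is available.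

Compound 4, `Nc1ccccc1NC(=O)c1ccc(CSCCc2ccccc2)cc1`, is not yet measured. It differs from compound 2 in one place: phenethyl in place of 4-bromophenyl on a sulfur. No comparison among the measured compounds isolates this kind of change, so the size and direction of the step are open. Given that compound 2 sits at 33.2% and nothing in the data points one way, a step from compound 2 to compound 4 of a number 4.8 percentage points higher from compound 2 to compound 4 (within the scatter) is expected, which is within the scatter. Compound 4 is thus estimated to give 38% in this assay, with a range from 20% to 56%.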

Compound 4, percent growth inhibition at one concentration: 44.9%
For compound 4 the middle estimate is 6.9 percentage points below the measured one; the measured number falls inside the stated range.
By their numbers in this assay, from the lowest: compound 2; then compounds 3 and 4 (each within the scatter of the next); then compound 1.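

In this assay, going by these compounds alone, the group on this sulfur proves open to change, as the first single-change comparison gives a number 11.7 percentage points higher from compound 2 to compound 4 (beyond the scatter) when phenethyl takes the place of 4-bromophenyl, a modest step beyond the scatter. Both groups carry one six-membered aromatic ring of carbon only and neither has hydrogen-bond donors or acceptors, so the change removes the bromine and places a saturated chain on the sulfur, and the number rises rather than falls. No accompanying measurement offers an explanation for this step.

As far as these compounds go, whether the rise belongs to the loss of the bromine or to the saturated chain stays open, as this one step changes both together, and an unsubstituted phenyl or a benzyl group on the sulfur would help to separate the two. Also open, from the compounds shown here alone, is how an amine, a carboxylic acid or a longer chain on this sulfur would fare, and whether the same exchange would give a similar step on the core of compound 1.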